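Replacing the Hydroxytriazole Side Chain with a Methylaminopyrimidine

The source may hold more compounds than are shown below. What is called first, only, known or untested is meant among the compounds shown, and "the series" means these compounds.

Three compounds built on the shared core were tested in a functional assay (aorta) with Rattus norvegicus as the target; a lower number here means a stronger inhibitor, a higher number a weaker inhibitor. Compound 1 `CCO/C(O)=C1\C(C)=NC(COCCNc2n[nH]c(N)n2)=C(C(=O)OC)C1c1cccc(Cl)c1Cl` gives 100 nM in this assay. Compound 2 `CCOC(=O)NC(=S)NCCOCC1=C(C(=O)OCC)C(c2cccc(Cl)c2Cl)/C(=C(\O)OC)C(C)=N1`, which carries a thiourea-bearing side chain, gives 31.6 nM in this assay. Compound 3 `CCO/C(O)=C1\C(COCCNc2n[nH]c(O)n2)=NC(C)=C(C(=O)OC)C1c1cccc(Cl)c1Cl` gives 10 nM in this assay and stands lowest of the three numbers; its nearest neighbour is compound 2, whose value lies beyond the usual scatter above it, and the furthest is compound 1, whose value lies still further beyond the scatter.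

Compound 4 `CCO/C(O)=C1\C(COCCNc2cc(NC)ncn2)=NC(C)=C(C(=O)OC)C1c1cccc(Cl)c1Cl` has not yet been measured. It differs from compound 3 in one place: 6-(methylamino)pyrimidin-4-yl in place of 5-hydroxy-1H-1,2,4-triazol-3-yl on an amine nitrogen. Among the compounds with values here, no measured pair in this set isolates a change of this kind, so the size of the step cannot be read from the data. Because compound 3 already gives 10 nM and the three measured values lie within a modest span, the expected outcome is a step of small size in the direction of a higher number, one that may or may not reach beyond the scatter. The expected step from compound 3 to compound 4 is a 2.0-fold higher number from compound 3 to compound 4 (0.30 log units; within the scatter). Compound 4 is therefore estimated at 20 nM, with a range from 6 nM to 70 nM.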

Compound 4, half-maximal inhibitory concentration: 3.16 nM
Estimate against measurement, compound 4: 6.3-fold (0.80 log units) above; measured number below the stated range.
By their numbers in this assay, from the lowest: compound 4; then compound 3; then compound 2; then compound 1.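

In this assay, within the data shown here, placing 6-(methylamino)pyrimidin-4-yl instead of 5-hydroxy-1H-1,2,4-triazol-3-yl on the amine nitrogen gave a 3.2-fold lower number from compound 3 to compound 4 (0.50 log units; beyond the scatter), the only step in this set that isolates a single change, and it lies beyond the usual scatter. It shows that the five-membered aromatic ring with 3 hetero atoms and its hydroxy group are not required at this position, since a six-membered aromatic ring with 2 hetero atoms and no oxygen, bearing a methylamino group, takes its place with no loss and a modest gain. No measured evidence here accounts for the size or direction of this step.

As far as these compounds go, whether the gain belongs to the pyrimidine ring or to its methylamino group stays open, and a plain amine or a dimethylamino group on the same ring would separate the two. Also open, from the compounds shown here alone, is how far the position tolerates further change, for instance a longer chain in place of the 2-((6-(methylamino)pyrimidin-4-yl)amino)ethyl unit or a methyl group on the amine nitrogen that joins the chain to the ring.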